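Changing the terminal amine on a flavone side chain

A few compounds are considered here, and "the series" means these few. Any claim that something is new, unique, unknown or untested is made for them only; others in the source may bear on it.

Compound 1 `O=c1cc(-c2ccccc2)oc2c(OCCCN3CCCC3)c(OCc3ccccc3)cc(O)c12` and compound 2 `O=c1cc(-c2ccccc2)oc2c(OCCCCN3CCCC3)c(OCc3ccccc3)cc(O)c12` share one core and differ only in the length of the chain carrying the amine. In a functional assay on A549 cells (Homo sapiens) for cytotoxicity, read by MTT assay, with a stated time of 72 h (a higher number here means a weaker inhibitor, a lower number a stronger inhibitor), compound 1 gives 4720 nM, and compound 2 gives 1100 nM; the step is a 4.3-fold lower number from compound 1 to compound 2 (0.63 log units; beyond the scatter). Compound 2 thus stands at the lowest of the two numbers measured. Compound 3 `CN1CCN(CCCCOc2c(OCc3ccccc3)cc(O)c3c(=O)cc(-c4ccccc4)oc23)CC1` carries 4-methylpiperazin-1-yl in place of pyrrolidin-1-yl on a saturated chain carbon, four bonds along the chain from an oxygen on an aromatic ring. For the measured compounds named here, no measured step alters the amine itself; the only known step, from compound 1 to compound 2, concerns chain length and not the identity of the ring, so it offers no direct guide. With nothing to indicate a swing in either direction, the expected change is none beyond the scatter, or at most a small move toward a higher number. Compound 3 is therefore estimated at 1600 nM in this assay, with a range from 600 nM to 4500 nM. This expectation amounts to a step of a 1.5-fold higher number from compound 2 to compound 3 (0.16 log units; within the scatter).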

Compound 3, half-maximal inhibitory concentration: 2910 nM
Estimate against measurement, compound 3: 1.8-fold (0.26 log units) below, and the stated range covers the measured number.
By their numbers in this assay, from the lowest: compound 2; then compounds 3 and 1 (each within the scatter of the next).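

In this assay, the identity of the terminal amine is shown to matter at this place, on a saturated chain carbon, four bonds along the chain from an oxygen on an aromatic ring: 4-methylpiperazin-1-yl in place of pyrrolidin-1-yl gives a 2.6-fold higher number from compound 2 to compound 3 (0.42 log units; beyond the scatter), so chain length is not the only feature that moves the number. The other new step, a 1.6-fold lower number from compound 1 to compound 3 (0.21 log units; within the scatter), changes both the chain and the amine, and the two compounds cannot be told apart in this assay. Nothing available explains the effect of the amine change.

The compounds shown leave open how a morpholine, a piperidine or a dimethylamino group would compare at the same place, and how pyrrolidin-1-yl would fare on a longer chain. They also leave open whether the amine step would be the same size on the shorter chain of compound 1.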